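Hydroxy to chloro on the six-membered aromatic ring

The source may hold more compounds than are shown below. What is called first, only, known or untested is meant among the compounds shown, and "the series" means these compounds.

Measured compounds:
Compound 1 `COc1ccc(C(=O)/C=C/c2cc3ccccc3[nH]c2=O)cc1` gives, in a functional assay on A549 cells (Homo sapiens) for cytotoxicity, read by sulforhodamine B assay, with a stated time of 24 h (on this read-out lower numbers stand for stronger inhibition of growth and higher numbers for weaker inhibition of growth), the limit > 100000 nM.
Compound 2 `O=C(/C=C/c1cc2ccccc2[nH]c1=O)c1ccc(O)cc1` gives in this assay 11800 nM.

Going by the values given here, compound 2 stands as the only compound with a real number in this assay; the value of compound 1 is a limit of the assay, as the limit of > 100000 nM in this assay, at which 1 of the 2 values shown sits, records, not a measured number. Among the compounds with values here, the one measured step, an at least 8.4-fold lower number from compound 1 to compound 2 (0.92 log units; beyond the scatter), puts hydrogen in place of methyl on the oxygen and reaches beyond the scatter.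

Compound 3 `O=C(/C=C/c1cc2ccccc2[nH]c1=O)c1ccc(Cl)cc1` differs from compound 2 by chloro in place of hydroxy on an aromatic carbon. This step bears no direct relation to the measured one: the earlier step changed what sits on the oxygen, whereas this step removes the oxygen and puts chlorine at the same aromatic carbon. The measured step shows that this position responds strongly to change, since the methyl form reached only a limit. The expected step of a 2.5-fold higher number from compound 2 to compound 3 (0.41 log units; beyond the scatter) is therefore taken as a weakening of modest size. The estimate for compound 3 in this assay is 30000 nM, expected between 8000 nM and 100000 nM.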

Compound 3, concentration for total growth inhibition: > 100000 nM
Compound 3 gave a limit, no number; the forecaster's own chance of this, stated with the estimate: 35%; middle value at least 3.3-fold (0.52 log units) away from the limit.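

Before this result, the only change at this position was capping the oxygen of the hydroxy group with methyl. Now the oxygen itself has been replaced, and chloro in place of hydroxy gives an at least 8.4-fold higher number from compound 2 to compound 3 (0.92 log units; beyond the scatter) in this assay, so the loss is not confined to the methoxy group of compound 1. For compound 3 the value > 100000 nM is a limit of the assay and not a number. Compound 1 and compound 3 both end at a limit, so the step between them cannot be read, and among these three compounds only the one with the 4-hydroxyphenyl group, compound 2, gives a real number: the limit of > 100000 nM in this assay, at which 2 of the 3 values shown sit.

Going by these compounds alone, what remains open is whether the hydroxy group is the only group at this aromatic carbon that gives a real number, or whether an amine or a carboxylic acid there would do the same. These three compounds also cannot say why hydroxy differs from methoxy and chloro, and they cannot show how far above the limit compound 1 and compound 3 truly lie.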